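The source may hold more compounds than are shown below. What is called first, only, known or untested is meant among the compounds shown, and "the series" means these compounds.

Measured compounds: compound 1 `COc1ccc(Oc2ccc(C(C)C)cc2-c2ccsc2S(=O)(=O)NCCNC(=S)Nc2cc(C(F)(F)F)cc(C(F)(F)F)c2)cc1OC`, compound 2 `CC(C)c1ccc(Oc2ccc(O)c(O)c2)c(-c2ccsc2S(=O)(=O)NCCNC(=S)Nc2cc(C(F)(F)F)cc(C(F)(F)F)c2)c1`, compound 3 `CC(C)c1ccc(Oc2ccc(O)c(O)c2)c(-c2ccsc2S(=O)(=O)NCCNC(=O)Nc2cc(C(F)(F)F)cc(C(F)(F)F)c2)c1`.

In a functional assay on HeLa cells (Homo sapiens) for inhibition, read by CCK-8 assay, with a stated time of 48 h (a lower number here means a stronger inhibitor, a higher number a weaker inhibitor), compound 1 gives 8300 nM. Compound 2 reaches only a limit of the assay, > 20000 nM, in this assay. Compound 3 likewise reaches only a limit, > 50000 nM, in this assay. Among the compounds with values here, the one counted change, (3,4-dimethoxyphenyl in place of 3,4-dihydroxyphenyl on an oxygen on an aromatic ring), made an at least 2.4-fold lower number from compound 2 to compound 1 (0.38 log units; beyond the scatter); this rests on (the limit of > 20000 nM in this assay, at which 1 of the 3 values shown sits). How the core of compound 3 differs from that of compound 2 is not broken down here.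

Compound 4 `COc1ccc(Oc2ccc(C(C)C)cc2-c2ccsc2S(=O)(=O)NCCNC(=O)Nc2cc(C(F)(F)F)cc(C(F)(F)F)c2)cc1OC` carries the same change on the core of compound 3, (3,4-dimethoxyphenyl in place of 3,4-dihydroxyphenyl on an oxygen on an aromatic ring). From the step seen in compound 1 against compound 2, an at least 2.4-fold lower number from compound 2 to compound 1 (0.38 log units; beyond the scatter), the step from compound 3 to compound 4 is expected to be an at least 2.5-fold lower number from compound 3 to compound 4 (0.39 log units; beyond the scatter), though compound 3 sits at a limit, (the limit of > 50000 nM in this assay, at which 1 of the 3 values shown sits), so the true size is open. Compound 4 is estimated at 20000 nM, expected between 6000 nM and 60000 nM in this assay.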

Compound 4, half-maximal inhibitory concentration: 11600 nM
Compound 4: the middle estimate sits 1.7-fold (0.24 log units) above what was measured; low and high end bracket the measured number.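

In this assay, 3,4-dimethoxyphenyl in place of 3,4-dihydroxyphenyl gave an at least 4.3-fold lower number from compound 3 to compound 4 (0.63 log units; beyond the scatter), so the direction of the step seen on the core of compound 2 also held on the core of compound 3. As far as these compounds go, compound 3 stands only at a limit of the assay, > 50000 nM, so the true size of its step is unknown. The two steps therefore show a shared direction on these two cores, but not a shared size: the same change on two cores in this assay, an at least 2.4-fold lower number (0.38 log units; beyond the scatter) from compound 2 to compound 1 and an at least 4.3-fold lower number (0.63 log units; beyond the scatter) from compound 3 to compound 4; the limit leaves it open whether they differ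

The compounds shown leave open how other groups would read in this place, such as a single methoxy group, a longer ethoxy chain or an amine. They also leave open whether the same direction would hold on any further core.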